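The source may report more compounds than this note shows. Statements on the series, on what has been measured and on what is new or still open speak of the compounds shown alone.

Of the compounds shown here, three have been measured in a physicochemical assay for lipophilicity; a lower number here means a more polar compound, a higher number a more lipophilic compound. Compound 1 `CNCC(=O)Nc1ccc(-c2nc(CS(C)(=O)=O)cc([C@]34CCOC[C@H]3C4)n2)cc1` gives 3.1, the lowest of the three numbers. Compound 2 `CS(=O)(=O)Cc1cc(C2=CCOCC2)nc(-c2cccc(O)c2)n1` gives 3.3, a number within the scatter of that of compound 1. Compound 3 `CCNC(=O)Nc1ccc(-c2nccc(C3=CCOCC3)n2)cc1` gives 3.6, a number beyond the scatter of that of compound 1. Going by the values given here, no two of these measured compounds differ in a single place, so no step between measured compounds can be read off. Compound 4 `CNCC(=O)Nc1ccc(-c2nc(CS(C)(=O)=O)cc([C@@]34CCOC[C@@H]3C4)n2)cc1` is not yet measured in this assay; it relates to compound 1 as follows: the two compounds have the same atoms and bonds and differ only in configuration as drawn: 2 of 2 stereo elements differ (all stereocentres are inverted: mirror images); a stereocentre at a saturated ring carbon is drawn R in compound 1 and S in compound 4; a stereocentre at a saturated ring carbon is drawn S in compound 1 and R in compound 4. With the same atoms and bonds and only the configuration differing, no step beyond the scatter is expected for no change at the digits printed from compound 1 to compound 4 (within the scatter). Compound 4 is thus expected to give 3.1, within 2.8 to 3.4.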

Compound 4, partition coefficient: 3.1
Compound 4: the middle estimate sits on the measured number at the digits printed, within the range that was stated.
By their numbers in this assay, from the lowest: compounds 1, 4, 2 and 3 (each within the scatter of the next, the first and the last beyond it).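

In this assay the mirror-image pair shows no change at the digits printed from compound 1 to compound 4 (within the scatter). Going by these compounds alone, this is the only step that can be read so far, and it shows that inverting both stereocentres at the saturated ring carbons leaves the number unmoved for this pair. The two compounds carry one kind of difference only: the fact that compounds 1 and 4 differ only in the configuration as drawn

Still open, going by these compounds, is a pair with only one of the two stereocentres inverted. Also open, on these data alone, is how far the number moves when atoms change, for instance with a carboxylic acid or a longer chain on the shared core.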